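From isopropyl to methyl on the amide nitrogen

The source may report more compounds than this note shows. Statements on the series, on what has been measured and on what is new or still open speak of the compounds shown alone.

Results in a functional assay on HCT-116 cells (Homo sapiens) for inhibition, read by sulforhodamine B assay, with a stated time of 48 h (a higher number here means a weaker inhibitor of growth, a lower number a stronger inhibitor of growth), so far
- compound 1 `CCN(C(=O)c1cc(C(C)C)c(O)cc1O)c1ccc(NC(=O)CCCCCCC(=O)NO)cc1` gives 3560 nM 
- compound 2 `CC(C)c1cc(C(=O)N(C)c2ccc(NC(=O)CCCCCCCC(=O)NO)cc2)c(O)cc1O` gives 1060 nM 
- compound 3 `CC(C)c1cc(C(=O)N(c2ccc(NC(=O)CCCCCCC(=O)NO)cc2)C(C)C)c(O)cc1O` gives > 10000 nM as a limit, not a number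

In this assay compound 3 stands at > 10000 nM and this is a limit of the assay, not a number. Compound 4 `CC(C)c1cc(C(=O)N(C)c2ccc(NC(=O)CCCCCCC(=O)NO)cc2)c(O)cc1O` has methyl in place of isopropyl on an amide-type nitrogen. The measured step that bears on this is an at least 2.8-fold higher number from compound 1 to compound 3 (0.44 log units; beyond the scatter), beyond the scatter, where the group on this same nitrogen grew and the number rose. Compound 2, with methyl on that nitrogen but a different chain, gives 1060 nM in this assay. Reversing that growth should therefore lower the number beyond the scatter. The estimated step is downward (an at least 7.6-fold lower number from compound 3 to compound 4 (0.88 log units; beyond the scatter)). Compound 4 is expected at about 1300 nM (estimated range 450 nM to 3800 nM).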

Compound 4, concentration for 50% growth inhibition: 830 nM
Compound 4: the middle estimate sits 1.6-fold (0.19 log units) above what was measured; low and high end bracket the measured number.
By their numbers in this assay, from the lowest: compounds 4 and 2 (each within the scatter of the next); then compound 1. At a limit, above all of these: compound 3.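

Methyl in place of isopropyl on this amide-type nitrogen gives an at least 12-fold lower number from compound 3 to compound 4 (1.08 log units; beyond the scatter), and that size is only a minimum, since the value for the isopropyl compound is a limit of the assay, not a number: the limit of > 10000 nM in this assay, at which 1 of the 4 values shown sits.

Among the compounds sharing this chain, the number rises as the group on the nitrogen grows, and even the smaller change gives a 4.3-fold lower number from compound 1 to compound 4 (0.63 log units; beyond the scatter). The change in chain, by contrast, gives a 1.3-fold lower number from compound 2 to compound 4 (0.11 log units; within the scatter), so here the nitrogen group matters more than that chain difference.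

As far as these compounds go, whether plain hydrogen on this nitrogen, or a group carrying an amine or a carboxylic acid, would lower the number further stays open.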